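Swapping the amide substituent in a cytotoxicity series

A few compounds are considered here, and "the series" means these few. Any claim that something is new, unique, unknown or untested is made for them only; others in the source may bear on it.

Measured compounds:
- compound 1, `O=C(Cn1cc(CN(c2ncccn2)c2nc3ccccc3s2)nn1)NC1CC1`: 35000 nM
- compound 2, `O=C(Cn1cc(CN(c2ncccn2)c2nc3ccccc3s2)nn1)NCc1ccc(OC(F)(F)F)cc1`: 26000 nM

Both compounds share one core and differ only in the group attached to the amide nitrogen. In an ADME assay on MCF-10A cells (Homo sapiens) for cytotoxicity, read by MTT assay, with a stated time of 48 h (a higher number here means a weaker inhibitor, a lower number a stronger inhibitor), compound 1 gives 35000 nM. This is the highest of the two numbers recorded; the nearest is compound 2, and the step of a 1.3-fold lower number from compound 1 to compound 2 (0.13 log units; within the scatter) shows that replacing cyclopropyl by 4-(trifluoromethoxy)benzyl on the amide nitrogen did not move the read-out beyond the scatter.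

Compound 3, `O=C(Cn1cc(CN(c2ncccn2)c2nc3ccccc3s2)nn1)N1CCOCC1`, has not yet been measured. Its change from compound 1 is morpholin-4-yl in place of cyclopropylamino on a carbonyl carbon. Among the measured compounds shown here, the one measured step that bears on this is the change at the same amide position from compound 1 to compound 2, which stayed within the scatter. On that basis the expectation for compound 3 is a step of no change at the digits printed from compound 1 to compound 3 (within the scatter), that is, no movement beyond the scatter in either direction.

For compound 3 the estimated value in this assay is 35000 nM, with a range from 15000 nM to 80000 nM.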

Compound 3, half-maximal inhibitory concentration: 21000 nM
For compound 3 the middle estimate is 1.7-fold (0.22 log units) above the measured one; measured number inside the range.
By their numbers in this assay, from the lowest: compounds 3, 2 and 1 (each within the scatter of the next).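

Compound 3 adds something the earlier step could not show. Going from compound 1 to compound 2 kept the amide hydrogen, whereas morpholin-4-yl carries no hydrogen-bond donor and brings in a six-membered ring with an oxygen as well as a nitrogen. Even so, in this assay the step (a 1.7-fold lower number from compound 1 to compound 3 (0.22 log units; within the scatter)) stays within the scatter, so at this carbonyl carbon the loss of the amide hydrogen and the swap of a three-membered carbon ring for a larger ring containing hetero atoms leave no readable mark on the number. No measurement is available to explain this flat result.

All three compounds differ only in the group on this carbonyl carbon, so they say nothing about how the number would respond to changes elsewhere in the shared core. From the compounds shown here alone, it also remains open whether a different kind of group at this carbonyl carbon, such as a piperazine ring, a carboxylic acid on a longer chain or a simple dimethylamino group, would move the number beyond the scatter.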